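This account rests on a few compounds, and the source may have more. Where it says the series, first, only, none or still open, it means among the compounds named here.

Compound 3 `Cn1cc(C2=C(c3nn(CCCn4ccnc4)c4ncccc34)C(=O)NC2=O)c2ccccc21` shows in a functional assay on ECa-109 cells (Homo sapiens) for antiproliferative activity, read by MTT assay, with a stated time of 48 h (a higher number here means a weaker inhibitor, a lower number a stronger inhibitor), only a limit, > 100000 nM. For the measured compounds named here, compound 2 `Cn1cc(C2=C(c3nn(CCCCn4ccnc4)c4ncccc34)C(=O)NC2=O)c2ccccc21` gives 23500 nM in this assay, and the sole measured change on this chain is an at least 4.2-fold higher number from compound 2 to compound 3 (0.62 log units; beyond the scatter). Compound 1 `Cn1cc(C2=C(c3nn(CCCN4CCCCC4)c4ncccc34)C(=O)N(c3ccccn3)C2=O)c2ccccc21` differs from compound 4 in a further place. In this assay compound 1 gives 7300 nM. Compound 4 `Cn1cc(C2=C(c3nn(CCCN4CCCCC4)c4ncccc34)C(=O)NC2=O)c2ccccc21` differs from compound 3 by piperidin-1-yl in place of 1H-imidazol-1-yl on a saturated chain carbon, three bonds along the chain from an aromatic nitrogen. Going by the values given here, that change has no measured counterpart here, so it can only be read alongside compound 1, which carries piperidin-1-yl on the same chain and returned a number rather than a limit. Compound 4 is therefore expected to sit below the limit, an expected step of an at least 5.0-fold lower number from compound 3 to compound 4 (0.69 log units; beyond the scatter). Compound 4 is estimated at 20000 nM, between 5000 nM and 80000 nM.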

Compound 4, half-maximal inhibitory concentration: 42300 nM
Beside the measured number, compound 4's estimate is 2.1-fold (0.33 log units) below it; measured number inside the range.
By their numbers in this assay, from the lowest: compound 1; then compounds 2 and 4 (each within the scatter of the next). At a limit, above all of these: compound 3.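

Piperidin-1-yl in place of 1H-imidazol-1-yl on this propyl chain gives, in this assay, an at least 2.3-fold lower number from compound 3 to compound 4 (0.37 log units; beyond the scatter), a step read from a limit, not a number, for compound 3: the limit of > 100000 nM in this assay, at which 1 of the 4 values shown sits. Set against the butyl-linked imidazole, the change is a 1.8-fold higher number from compound 2 to compound 4 (0.26 log units; within the scatter), so these two are not told apart. Hydrogen in place of pyridin-2-yl on the amide-type nitrogen gives a 5.8-fold higher number from compound 1 to compound 4 (0.76 log units; beyond the scatter), so with piperidin-1-yl on the chain, the number depends on that ring nitrogen's substituent as well.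

Open, from the compounds shown here alone, is how morpholin-4-yl or dimethylamino would read on this chain. Also open, going by these compounds, is whether pyridin-2-yl on that nitrogen would bring a similar step with 1H-imidazol-1-yl on the chain.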